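The compounds below may be only part of what the source reports. "The series", "measured", "known", "first", "only" and "open" are said of these compounds alone.

Three ureas built on one shared core have been measured in a functional assay on HepG2 cells (Homo sapiens) for inhibition, read by MTT assay, with a stated time of 72 h; a lower number here means a stronger inhibitor, a higher number a weaker inhibitor. Compound 1 `N#Cc1ccccc1-n1cc(COc2cccc(NC(=O)Nc3ccc(Cl)c(C(F)(F)F)c3)c2)nn1` gives 1970 nM. Compound 2 `O=C(Nc1cccc(OCc2cn(-c3cccc(F)c3)nn2)c1)Nc1ccc(Cl)c(C(F)(F)F)c1` gives 2120 nM, and compound 3 `O=C(Nc1cccc(OCc2cn(-c3cccc(Cl)c3)nn2)c1)Nc1ccc(Cl)c(C(F)(F)F)c1` gives 2020 nM. Compound 3 stands second highest of the three numbers, with compound 1 nearest to it and compound 2 furthest, and every step among these three lies within the scatter: a 1.1-fold higher number from compound 1 to compound 2 (0.03 log units; within the scatter), a 1.0-fold higher number from compound 1 to compound 3 (0.01 log units; within the scatter) and a 1.0-fold lower number from compound 2 to compound 3 (0.02 log units; within the scatter).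

Compound 4 `COc1ccccc1-n1cc(COc2cccc(NC(=O)Nc3ccc(Cl)c(C(F)(F)F)c3)c2)nn1` has not yet been measured. It differs from compound 3 in one place: 2-methoxyphenyl in place of 3-chlorophenyl on an aromatic nitrogen. All three measured steps bear on this change, since each exchanges the aryl group on that same aromatic nitrogen, and none of them moved the number beyond the scatter. The step from compound 3 to compound 4 is therefore expected to be a 1.0-fold lower number from compound 3 to compound 4 (0.00 log units; within the scatter), which is no change beyond the scatter. For compound 4 the estimated value in this assay is 2000 nM, with a range from 1000 nM to 4000 nM.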

Compound 4, half-maximal inhibitory concentration: 11300 nM
For compound 4 the middle estimate is 5.7-fold (0.75 log units) below the measured one; the whole stated range lies below it.
By their numbers in this assay, from the lowest: compounds 1, 3 and 2 (each within the scatter of the next); then compound 4.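

In this assay, the aryl group on this aromatic nitrogen proves not to be freely exchangeable: 2-methoxyphenyl gives a 5.6-fold higher number from compound 3 to compound 4 (0.75 log units; beyond the scatter) and a 5.3-fold higher number from compound 2 to compound 4 (0.73 log units; beyond the scatter), whereas the three earlier aryl groups stayed within the scatter of one another. The closest comparison is a 5.7-fold higher number from compound 1 to compound 4 (0.76 log units; beyond the scatter), in which only methoxy replaces cyano on an aromatic carbon, so in this pair the higher number goes with methoxy and not with the mere presence of a group at that place on the phenyl ring. Nothing in the data shown explains this step.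

The compounds shown leave open whether a hydroxy, ethoxy or dimethylamino group at that same place would behave like methoxy or like cyano. They also leave open whether 3-methoxyphenyl would stand with 2-methoxyphenyl or with 3-chlorophenyl and 3-fluorophenyl.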